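A few compounds are considered here, and "the series" means these few. Any claim that something is new, unique, unknown or untested is made for them only; others in the source may bear on it.

Measured compounds in the series:

compound 2 `C=CCn1c(=O)/c(=C\c2cccc(F)c2)[nH]c(=O)/c1=C\c1ccccc1OC`: 8890 nM
compound 1 `COc1ccccc1/C=c1/[nH]c(=O)/c(=C\c2ccccc2OC)[nH]c1=O`: "not active" (no number reported)
compound 3 `C=CCn1c(=O)/c(=C\c2cccc(Br)c2)[nH]c(=O)/c1=C\c1cccc(Br)c1`: "not active" (no number reported)

For the measured compounds named here, in a functional assay on HL-60 cells (Homo sapiens) for cytotoxicity, read by CCK-8 assay, with a stated time of 72 h (on this read-out higher numbers stand for weaker inhibition and lower numbers for stronger inhibition), compound 2 is the only entry with a number. Going by the values given here, compound 1 and compound 3 were each reported as not active and no number was given for either, so they set no scale against which compound 2 can be ordered; the one number stands alone. Among the compounds with values here, no pair of measured compounds differs in a single place, so no step size is known from the data itself.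

Compound 4 `C=CCn1c(=O)/c(=C\c2cccc(Cl)c2Cl)[nH]c(=O)/c1=C\c1ccccc1OC` has not been measured. Against compound 2 the change is 2,3-dichlorophenyl in place of 3-fluorophenyl on a double-bonded chain carbon bound to an aromatic carbon. With nothing measured on either side of this change, the expectation is a step no larger than the usual scatter, in no set direction, and the estimated step from compound 2 to compound 4 is a 1.1-fold lower number from compound 2 to compound 4 (0.05 log units; within the scatter). Two of the three measured compounds returned no number, so a similar outcome for compound 4 cannot be excluded. Compound 4 is expected to give about 8000 nM, with a range from 3000 nM to 25000 nM.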

Compound 4, half-maximal inhibitory concentration: 2000 nM
Compound 4: the middle estimate sits 4.0-fold (0.60 log units) above what was measured, and the stated range ends above it.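

In this assay, for the compounds shown here, the exchange of 3-fluorophenyl for 2,3-dichlorophenyl on a double-bonded chain carbon bound to an aromatic carbon gives a 4.4-fold lower number from compound 2 to compound 4 (0.65 log units; beyond the scatter), the first step that can be read, and it shows that the number responds to the aryl group at this position. The rest of the structure is the same in both compounds, and neither group carries a hydrogen-bond donor, a hydrogen-bond acceptor or a net charge, so the step is reached by changing only the halogen substitution on a six-membered aromatic ring of carbon only. No available measurement bears on the reason for this step.

A single pair leaves open whether the step belongs to the chlorine atoms themselves or to their placement on the ring, and whether the same exchange would give a similar step with a different group on the rest of the structure. It also leaves open how an amine or a carboxylic acid on this aromatic ring would read in this assay.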